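Swapping the phenyl of compound 1 for cyclopropylmethyl

The source may report more compounds than this note shows. Statements on the series, on what has been measured and on what is new or still open speak of the compounds shown alone.

Compound 1 `O=C(NCc1cc(Cl)ccc1-n1cnnn1)[C@@H]1[C@H]2C[C@H]2CN1C(=O)[C@H](O)c1ccccc1`: 960 nM
Compound 2 `O=C(NCc1cc(Cl)ccc1-n1cnnn1)[C@@H]1[C@@H]2C[C@@H]2CN1C(=O)[C@H](O)c1ccccc1`: 700 nM

In a functional assay on a cell-free system (plasma, Homo sapiens), with a stated time of 3 min (a lower number here means a stronger inhibitor, a higher number a weaker inhibitor), compound 1 gives 960 nM and compound 2 gives 700 nM, so the two sit within the scatter of each other. Among the measured compounds shown here, the only measured step is a 1.4-fold lower number from compound 1 to compound 2 (0.14 log units; within the scatter), and it concerns configuration alone. Compound 3 `O=C(NCc1cc(Cl)ccc1-n1cnnn1)[C@@H]1[C@H]2C[C@H]2CN1C(=O)[C@H](O)CC1CC1` instead has cyclopropylmethyl in place of phenyl on a saturated chain carbon bound to a carbonyl carbon and an oxygen on a saturated carbon. For the measured compounds named here, no measured step touches this group, so the expectation stays loose. The estimated step in this assay, towards a weaker inhibitor, is a 2.6-fold higher number from compound 1 to compound 3 (0.42 log units; beyond the scatter). For compound 3 the estimate is 2500 nM, with an expected range from 600 nM to 10000 nM.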

Compound 3, half-maximal inhibitory concentration: 1400 nM
Estimate against measurement, compound 3: 1.8-fold (0.25 log units) above; the measured number falls inside the stated range.
By their numbers in this assay, from the lowest: compounds 2, 1 and 3 (each within the scatter of the next).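

Where the earlier pair differed only in configuration, this result changes the group itself, on a saturated chain carbon bound to a carbonyl carbon and an oxygen on a saturated carbon. this assay gives a 1.5-fold higher number from compound 1 to compound 3 (0.16 log units; within the scatter) for this change, so here a six-membered aromatic ring and a three-membered non-aromatic ring, each on its own group, read alike. Nothing available explains why these two groups give such similar numbers.

As far as these compounds go, whether an amine or a longer chain at this place would read alike remains open. So does the same swap on the core of compound 2.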